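This account rests on a few compounds, and the source may have more. Where it says the series, first, only, none or still open, it means among the compounds named here.

In a functional assay on MCF7 cells (Homo sapiens) for antiproliferative activity, read by sulforhodamine B assay, with a stated time of 72 h, tested at 10 uM (on this read-out lower numbers stand for a stronger effect and higher numbers for a weaker effect at the one concentration tested), compound 3 `COc1cccc(C(=O)CC2C(C#N)=C(N)Oc3ccc(Br)cc32)c1` gives 51.2%. That is the lowest of the three numbers measured, but the other two sit close by: compound 1 `COc1cc(Br)cc(/C=C/C(=O)c2ccc(Cl)cc2)c1O` gives 53.3%, and compound 2 `COc1cccc(C(=O)CC2C(C#N)=C(N)Oc3c(OC)cc(Br)cc32)c1` gives 55.9%, so none of the three can be told apart. Going by the values given here, the only one-place step among them, a number 4.7 percentage points lower from compound 2 to compound 3 (within the scatter), changes a group on the shared core and not the ring attached to the carbonyl.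

Compound 4 `Cc1ccc(C(=O)CC2C(C#N)=C(N)Oc3ccc(Br)cc32)cc1` differs from compound 3 by 4-methylphenyl in place of 3-methoxyphenyl on a carbonyl carbon. Among the compounds with values here, no measured step touches this ring, so the expectation for compound 4 can rest only on the measured compounds showing nothing beyond the scatter so far. The step from compound 3 to compound 4 is therefore expected to be small, a number 0.8 percentage points higher from compound 3 to compound 4 (within the scatter), in no particular direction. In this assay compound 4 is estimated to give 52%, expected between 38% and 66%.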

Compound 4, a percentage reported as activity, at one concentration (the size of the read-out at that concentration, not a potency): 69%
Compound 4: middle estimate off by 17 percentage points, on the low side, and the stated range ends below it.
By their numbers in this assay, from the lowest: compounds 3, 1 and 2 (each within the scatter of the next); then compound 4.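

In this assay, the ring on the carbonyl carbon turns out to matter: a number 17.8 percentage points higher from compound 3 to compound 4 (beyond the scatter), and on this read-out a higher number stands for a weaker effect at the one concentration tested. This is the first step among the compounds shown that lies beyond the scatter, so this position can change the result, whereas the earlier step on the shared core did not show a clear change. The step replaces 3-methoxyphenyl with 4-methylphenyl, so both the group on the ring and its place on the ring change at once, and this single comparison cannot separate the two.

As far as these compounds go, it remains open whether 3-methylphenyl or 4-methoxyphenyl would stay close to compound 3 or to compound 4, and what an amine or a carboxylic acid on this ring would do. No measurement shown gives a reason for this step.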